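Swapping the pyridinone on the isoxazole of compound 1

The source may report more compounds than this note shows. Statements on the series, on what has been measured and on what is new or still open speak of the compounds shown alone.

Measured so far:
compound 1, `Cc1cc(OCc2c(-c3[nH]c(=O)ccc3Cl)noc2C(C)C)ccc1-c1ccc2c(C(=O)O)cn(C)c2c1`: 18000 nM
compound 2, `CC(C)c1onc(-c2c(Cl)cncc2Cl)c1COc1ccc(/C=C/c2cccc(C(=O)O)c2)c(Cl)c1`: 11000 nM

Both were tested in a functional assay for agonist activity at Bile acid receptor (Mus musculus), read by a luciferase reporter; a lower number here means that less compound is needed, a higher number that more compound is needed for the effect. Compound 1 gives 18000 nM, and compound 2 gives 11000 nM; the two values lie within the usual scatter of each other, so neither can be called the weaker. Compound 3, `Cc1cc(OCc2c(-c3ccn(C)c(=O)c3Cl)noc2C(C)C)ccc1-c1ccc2c(C(=O)O)cn(C)c2c1`, has not been measured. It differs from compound 1 in one place: a group of 9 heavy atoms (6 carbon, 1 nitrogen, 1 oxygen, 1 chlorine; one six-membered aromatic ring with 1 hetero atom) in place of a group of 8 heavy atoms (5 carbon, 1 nitrogen, 1 oxygen, 1 chlorine; one six-membered aromatic ring with 1 hetero atom), on an aromatic carbon. Among the measured compounds shown here, no measured pair shows such a change, so the size of the step is unknown. A step for compound 3 of a 1.3-fold lower number from compound 1 to compound 3 (0.11 log units; within the scatter) is expected, not beyond the scatter. Compound 3 is estimated at 14000 nM, in the range 4000 nM to 50000 nM.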

Compound 3, half-maximal effective concentration: 6000 nM
Compound 3: the middle estimate sits 2.3-fold (0.37 log units) above what was measured; low and high end bracket the measured number.
By their numbers in this assay, from the lowest: compounds 3, 2 and 1 (each within the scatter of the next, the first and the last beyond it).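

In this assay, the exchange gives a 3.0-fold lower number from compound 1 to compound 3 (0.48 log units; beyond the scatter), and the entering group has 0 hydrogen-bond donors where the leaving group has 1. This shows that the number responds, modestly, to the group on this aromatic carbon of the five-membered aromatic ring with 1 nitrogen and 1 oxygen. No measurement at hand explains the step.

Whether the loss of the donor alone accounts for the step stays open, since the two groups also differ in other ways. So does the effect of a plain phenyl ring or an amine-bearing ring at this position.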